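Sulfonamide nitrogen methylation: compound 2 to compound 3

The compounds below may be only part of what the source reports. "The series", "measured", "known", "first", "only" and "open" are said of these compounds alone.

- compound 1 `CCCCCCNc1ccc([N+](=O)[O-])cc1S(=O)(=O)N(C)C` 1000 nM
- compound 2 `CCCCCCNc1ccc(C(=O)O)cc1S(=O)(=O)NC` 247000 nM

In a physicochemical assay for solubility, in phosphate buffer, measured as kinetic solubility, at pH 7.4, tested at 250 uM (a higher number here means a more soluble compound, a lower number a less soluble compound), compound 2 holds the higher of the two numbers, and compound 1 lies lower by far more than the scatter of repeated measurements. These two compounds differ in more than one place, so their gap cannot be assigned to any single change.

One change leads from compound 2 to compound 3 `CCCCCCNc1ccc(C(=O)O)cc1S(=O)(=O)N(C)C` and its count reads methyl in place of hydrogen on a sulfonamide nitrogen with methyl in place of hydrogen on a sulfonamide nitrogen. Going by the values given here, no measured pair isolates this change, so this assay offers no direct precedent for its size. With compound 2 at 247000 nM close to the top concentration tested, little room remains upward, and a small downward step, possibly none beyond the scatter, is expected. The expected step of a 1.5-fold lower number from compound 2 to compound 3 (0.16 log units; within the scatter) is only an estimate and carries wide uncertainty. For compound 3 the estimated value is 170000 nM with an expected range from 60000 nM to 250000 nM in this read-out.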

Compound 3, solubility: 243000 nM
For compound 3 the middle estimate is 1.4-fold (0.16 log units) below the measured one; the range from low to high includes it.
By their numbers in this assay, from the lowest: compound 1; then compounds 3 and 2 (each within the scatter of the next).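

In this assay, methyl in place of hydrogen on the sulfonamide nitrogen gives a 1.0-fold lower number from compound 2 to compound 3 (0.01 log units; within the scatter), so with a carboxy group on the shared core the two compounds cannot be told apart at this position. Compound 3 also supplies the single-place comparison that compound 1 and compound 2 could not give: carboxy in place of nitro on an aromatic carbon comes with a 240-fold higher number from compound 1 to compound 3 (2.39 log units; beyond the scatter), a large step that now belongs to one named change. No measurement in hand bears on the reason for either step.

On these data alone, both compound 2 and compound 3 stand close to the top concentration tested, so the methyl step is read only within that narrow room, and its size with nitro in place of carboxy remains unknown. Also open, as far as these compounds go, is where other groups on that aromatic carbon, such as an amine or a nitrile, or a longer chain in place of the present one, would fall relative to compound 1 and compound 3.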